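Second methoxy on the aryl ketone of the hydroxamate series

The source may report more compounds than this note shows. Statements on the series, on what has been measured and on what is new or still open speak of the compounds shown alone.

Measured so far:
compound 1 `Cc1ccc(C(=O)c2ccc3c(ccn3S(=O)(=O)c3cccc(/C=C/C(=O)NO)c3)c2)cc1` — 4480 nM
compound 2 `COc1ccc(C(=O)c2ccc3c(ccn3S(=O)(=O)c3cccc(/C=C/C(=O)NO)c3)c2)cc1` — 812 nM

In an assay on isolated protein for inhibition of histone deacetylase 8 (Homo sapiens) (a higher number here means a weaker inhibitor, a lower number a stronger inhibitor), compound 1 gives 4480 nM and compound 2 gives 812 nM. For the measured compounds named here, the single step between them, a 5.5-fold lower number from compound 1 to compound 2 (0.74 log units; beyond the scatter), is the only change measured. Going by the values given here, compound 2 therefore stands at the lowest number of the two, with compound 1 as its only neighbour.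

Compound 3 `COc1ccc(C(=O)c2ccc3c(ccn3S(=O)(=O)c3cccc(/C=C/C(=O)NO)c3)c2)cc1OC` differs from compound 2 by methoxy in place of hydrogen on an aromatic carbon. Among the compounds with values here, no measured step shares this change; the step from compound 1 to compound 2 swaps one group for another at a different site, so it bears on compound 3 only as a sign that this part of the molecule is tolerant of small variation. The expectation for compound 3 in this assay is a step of about a 1.4-fold lower number from compound 2 to compound 3 (0.13 log units; within the scatter), which lies within the scatter, with no firm direction. The estimate for compound 3 is 600 nM, ranging from 250 nM to 1800 nM.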

Compound 3, half-maximal inhibitory concentration: 1420 nM
Compound 3: middle estimate off by 2.4-fold (0.37 log units), on the low side; the range from low to high includes it.
By their numbers in this assay, from the lowest: compounds 2 and 3 (each within the scatter of the next); then compound 1.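

In this assay, the change from 4-methoxyphenyl to 3,4-dimethoxyphenyl gives a 1.7-fold higher number from compound 2 to compound 3 (0.24 log units; within the scatter), so a second methoxy ortho to the first is accommodated on this ring without a readable change in the number. The 3,4-dimethoxyphenyl group in place of 4-methylphenyl gives a 3.2-fold lower number from compound 1 to compound 3 (0.50 log units; beyond the scatter), which places both methoxy-bearing compounds clear of the methyl compound, with compound 2 and compound 3 not separable from each other. No evidence in hand bears on this result.

Still open, as far as these compounds go, is whether a larger or charged group at this position, such as an ethoxy group, an amine or a carboxylic acid, would move the number beyond the scatter. From the compounds shown here alone, the effect of a hydroxyl group here in place of the new methoxy is also open.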